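Methyl on the ring-nitrogen amine: cytotoxicity working notes

The source may report more compounds than this note shows. Statements on the series, on what has been measured and on what is new or still open speak of the compounds shown alone.

Working notes on a small series read in an ADME assay on cells (Homo sapiens) for cytotoxicity, read by polymerase chain reaction, with a stated time of 3 days; on this read-out lower numbers stand for higher toxicity in this test and higher numbers for lower toxicity in this test. For the measured compounds named here, compound 1 `Nc1nc(Cl)c(-c2ncco2)c(N[C@@H]2C[C@H](CO)[C@@H](O)[C@H]2O)n1` is the first member. In this assay compound 1 gives > 25000 nM, which is a limit of the assay and not a number. Compound 2 `Nc1ncc(-c2nc3ccccc3s2)c(N[C@@H]2C[C@H](CO)[C@@H](O)[C@H]2O)n1` in this assay gives > 25000 nM, again a limit only. Compound 3 `CNc1nc(C)c(-c2nc3ccccc3s2)c(N[C@@H]2C[C@H](CO)[C@@H](O)[C@H]2O)n1` in this assay gives > 25000 nM, also a limit. Every value in hand thus sits at the same point, (the limit of > 25000 nM in this assay, at which 3 of the 3 values shown sit), so compound 3 cannot be placed higher or lower than the other two; the three show only that no toxicity was seen within the tested range.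

Compound 4 `Cc1nc(N(C)C)nc(N[C@@H]2C[C@H](CO)[C@@H](O)[C@H]2O)c1-c1nc2ccccc2s1` is not yet measured. It differs from compound 3 by methyl in place of hydrogen on a nitrogen on an aromatic ring, that is methylamino to dimethylamino. Going by the values given here, no step between measured compounds exists, so there is no measured precedent for this change in this assay. The step is expected to be none beyond the scatter, a step that the limit leaves unreadable from compound 3 to compound 4, given that compound 3 sits at > 25000 nM. For compound 4 the expected value in this assay is 40000 nM, with a range from 15000 nM to 120000 nM, most likely reported again as a limit.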

Compound 4, half-maximal cytotoxic concentration: 18000 nM
Compound 4: middle estimate off by 2.2-fold (0.35 log units), on the high side; the measured number falls inside the stated range.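

For the compounds shown here, compound 4 is the first member of the series with a number and not a limit: in this assay compound 4 gives 18000 nM. At this nitrogen on an aromatic ring, methylamino to dimethylamino gives an at least 1.3-fold lower number from compound 3 to compound 4 (0.14 log units; that floor lies within the scatter), so the change leaves a readable cytotoxic concentration, but the size of the step is only a floor. On these data alone, the true step stays unknown because compound 3 is held at a limit: the limit of > 25000 nM in this assay, at which 3 of the 4 values shown sit.

Open, as far as these compounds go, is whether a longer chain on this nitrogen, such as ethyl in place of one methyl, or a cyclic amine such as pyrrolidine in place of the dimethylamino group, would give a number in this assay or return to the limit. Also open is whether a second methyl on this nitrogen has the same outcome on the other cores shown.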